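A benzyl ether swap on a benzimidazole acylurea series

The source may report more compounds than this note shows. Statements on the series, on what has been measured and on what is new or still open speak of the compounds shown alone.

The series shares one core and varies the benzyl ether at its far end. Compound 1 `Cc1ccc(NC(=S)NC(=O)c2ccc(OCc3cccc(C(F)(F)F)c3)cc2)cc1-c1nc2ccccc2[nH]1` gives 5210 nM in a functional assay on MGC-803 cells (Homo sapiens) for inhibition, read by MTT assay, with a stated time of 48 h; a lower number here means a stronger inhibitor, a higher number a weaker inhibitor. Compound 2 `Cc1ccc(NC(=O)NC(=O)c2ccc(OCc3ccccc3)cc2)cc1-c1nc2ccccc2[nH]1` gives 39400 nM, and compound 3 `Cc1ccc(NC(=O)NC(=O)c2ccc(OCc3cccc(Cl)c3)cc2)cc1-c1nc2ccccc2[nH]1` gives 20800 nM, the second highest of the three numbers. Among the measured compounds shown here, the only single-point step among the measured compounds is a 1.9-fold lower number from compound 2 to compound 3 (0.28 log units; within the scatter), so the chloro added to the benzyl ring brought no change that can be told from repeat measurement. Compound 1 sits at a lower number than compound 3, but the two differ in more than one place, so nothing can be read from that pair about the benzyl ring alone.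

Compound 4 `Cc1ccc(NC(=O)NC(=O)c2ccc(OCc3ccc(C(F)(F)F)cc3)cc2)cc1-c1nc2ccccc2[nH]1` is the next step from compound 3: 4-(trifluoromethyl)phenyl in place of 3-chlorophenyl on a saturated chain carbon bound to an oxygen on an aromatic ring. For the measured compounds named here, the one step that bears on it, from compound 2 to compound 3, was within the scatter, and no measured pair isolates the trifluoromethyl on this ring within the acylurea series. The expected step of a 1.4-fold lower number from compound 3 to compound 4 (0.14 log units; within the scatter) in this assay is therefore small, with little basis to call a direction. Compound 4 is estimated to give about 15000 nM, expected to fall between 6000 nM and 40000 nM.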

Compound 4, half-maximal inhibitory concentration: 14900 nM
Estimate against measurement, compound 4: 1.0-fold (0.00 log units) above; the range from low to high includes it.
By their numbers in this assay, from the lowest: compound 1; then compounds 4, 3 and 2 (each within the scatter of the next, the first and the last beyond it).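

In this assay, a 2.6-fold lower number from compound 2 to compound 4 (0.42 log units; beyond the scatter) is the only step shown that lies beyond the scatter, a modest one, which adds a trifluoromethyl group to the benzyl ring. This gives the first sign that a substituent on the benzyl ring can shift the number in the acylurea series, although chloro in the step of a 1.9-fold lower number from compound 2 to compound 3 (0.28 log units; within the scatter) stays within the scatter and so goes against any general claim for substituents on that ring. Exchanging 3-chlorophenyl for 4-(trifluoromethyl)phenyl on a saturated chain carbon bound to an oxygen on an aromatic ring gives a 1.4-fold lower number from compound 3 to compound 4 (0.14 log units; within the scatter), which leaves these two substituted benzyl ethers indistinguishable, and nothing shown here offers a reason for either step.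

The compounds shown do not separate the identity of the substituent from its place on the ring, as no pair sets 3-(trifluoromethyl)benzyl against 4-(trifluoromethyl)benzyl within one series, and no single-place pair isolates the sulfur of compound 1 against the carbonyl oxygen of the others. Going by these compounds, how an amine, a carboxylic acid or a methoxy group on the benzyl ring would read in this assay also remains open.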